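A few compounds are considered here, and "the series" means these few. Any claim that something is new, unique, unknown or untested is made for them only; others in the source may bear on it.

Compound 1 `COc1cc(-c2nnc(SCC(=O)c3ccccc3F)n2N)cc(OC)c1OC` gives 43100 nM in a functional assay on PC-3 cells (Homo sapiens) for antiproliferative activity, read by MTT assay, with a stated time of 48 h; on this read-out higher numbers stand for weaker inhibition and lower numbers for stronger inhibition. Compound 2 `COc1ccc(C(=O)CSc2nnc(-c3cc(OC)c(OC)c(OC)c3)n2N)cc1` gives 97900 nM. Compound 3 `COc1cc(-c2nnc(SCC(=O)Nc3ccccc3C)n2N)cc(OC)c1OC` gives > 100000 nM, which is a limit of the assay.

Compound 3 thus stands at the weak end of the shown numbers, and only as a limit, namely (the limit of > 100000 nM in this assay, at which 1 of the 3 values shown sits). Compound 4 `COc1cc(-c2nnc(SCC(=O)NCc3ccc(Cl)cc3)n2N)cc(OC)c1OC` differs from compound 3 in one place: 4-chlorobenzyl in place of 2-methylphenyl on an amide-type nitrogen. Among the compounds with values here, no measured step alters the group on the amide-type nitrogen; the steps that end at compound 3, an at least 2.3-fold higher number from compound 1 to compound 3 (0.36 log units; beyond the scatter) and an at least 1.0-fold higher number from compound 2 to compound 3 (0.00 log units; that floor lies within the scatter), concern the exchange of a ketone for the amide and so bear on it only indirectly. For compound 4 no step beyond the scatter is expected, a number no higher from compound 3 to compound 4 (the limit leaves the size open). Compound 4 is therefore estimated at 100000 nM, between 30000 nM and 300000 nM, with a fair chance that only a limit is reported again.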

Compound 4, half-maximal inhibitory concentration: > 100000 nM
Compound 4: a limit, no number (the forecaster's own chance of this, stated with the estimate: 65%); the middle value lies on the limit itself.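

Compound 4 also gives only a limit in this assay, so a second group on the amide-type nitrogen yields no number and the step from compound 3 to compound 4 cannot be read. Measured against the ketones, the record shows an at least 2.3-fold higher number from compound 1 to compound 4 (0.36 log units; beyond the scatter) and an at least 1.0-fold higher number from compound 2 to compound 4 (0.00 log units; that floor lies within the scatter), so only compound 1 stands apart from this amide beyond the scatter. The two amides now share one ceiling: the limit of > 100000 nM in this assay, at which 2 of the 4 values shown sit.

Going by these compounds, whether any group on this nitrogen gives a number remains open. A plain benzyl, a 2-phenylethyl chain or a 4-carboxybenzyl might still do so, and nothing here tells how far they would move the value.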